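The source may hold more compounds than are shown below. What is called first, only, known or untested is meant among the compounds shown, and "the series" means these compounds.

In a functional assay on A375P cells (Homo sapiens) for antiproliferative activity, read by MTT assay, with a stated time of 48 h (a lower number here means a stronger inhibitor, a higher number a weaker inhibitor), compound 3 `CC(=O)Nc1cccc2c(-c3cccc(NC(=O)c4ccc(F)c(C(F)(F)F)c4)c3)ccnc12` gives 6800 nM, the lower of the two numbers shown, though the gap to compound 2 `CC(=O)Nc1cccc2c(-c3cccc(NC(=O)c4cccc(C(F)(F)F)c4)c3)ccnc12` at 8000 nM is within the scatter: a 1.2-fold lower number from compound 2 to compound 3 (0.07 log units; within the scatter). Compound 1 `CC(=O)Nc1cccc2c(-c3cccc(NC(=O)c4ccc(Br)c(C)c4)c3)ccnc12` gives only a limit in this assay, > 20000 nM. From there the steps are an at least 2.5-fold lower number from compound 1 to compound 2 (0.39 log units; beyond the scatter) and an at least 2.9-fold lower number from compound 1 to compound 3 (0.46 log units; beyond the scatter), both resting on (the limit of > 20000 nM in this assay, at which 1 of the 3 values shown sits).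

Compound 4 `CC(=O)Nc1cccc2c(-c3cccc(NC(=O)c4ccc(Cl)cc4C(F)(F)F)c3)ccnc12` carries 4-chloro-2-(trifluoromethyl)phenyl in place of 4-fluoro-3-(trifluoromethyl)phenyl on a carbonyl carbon. Within the data shown here, no measured step relocates the trifluoromethyl group or exchanges fluoro for chloro on that ring; the one step that alters the same ring, from compound 2 to compound 3, stayed within the scatter. Among the measured compounds shown here, with no step bearing directly on this change, compound 4 is expected near compound 3, with a wide range: a 1.3-fold higher number from compound 3 to compound 4 (0.12 log units; within the scatter), estimated at 9000 nM (3000 nM to 27000 nM).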

Compound 4, half-maximal inhibitory concentration: > 20000 nM
Compound 4 was reported as a limit; the forecaster's own chance of this, stated with the estimate: 25%; middle value at least 2.2-fold (0.34 log units) away from the limit.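

In this assay the change on the carbonyl carbon to 4-chloro-2-(trifluoromethyl)phenyl gives an at least 2.9-fold higher number from compound 3 to compound 4 (0.46 log units; beyond the scatter) and an at least 2.5-fold higher number from compound 2 to compound 4 (0.39 log units; beyond the scatter), so a trifluoromethyl group on this ring does not alone keep a measurable number. Compound 4 gives > 20000 nM, which is a limit, and both steps rest on it: the limit of > 20000 nM in this assay, at which 2 of the 4 values shown sit. The step between compound 1 and compound 4 cannot be read.

Compound 4 alters the trifluoromethyl placement and the halogen together, leaving their separate contributions open. Going by these compounds, how an amine or a carboxylic acid on this ring would read also stays open.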